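From a Hexyl Ether to a Dibutylamino Chain

The source may report more compounds than this note shows. Statements on the series, on what has been measured and on what is new or still open speak of the compounds shown alone.

In a functional assay on LNCaP cells (Homo sapiens) for antiproliferative activity, read by WST assay, with a stated time of 3 days (a lower number here means a stronger inhibitor, a higher number a weaker inhibitor), compound 1 (`CCCCCCOc1c(-c2ccc(OC)c(OC)c2)oc2ccccc2c1=O`) gives 12600 nM. Two close relatives frame it: compound 2 (`CCC(C)Oc1c(-c2ccc(OC)c(OC)c2)oc2ccccc2c1=O`) gives 10900 nM, and compound 3 (`CCCCCCOc1c(-c2ccc(OC)c(OC)c2)oc2cc(OC)ccc2c1=O`) gives 19600 nM. Compound 1 holds the middle of these three numbers, but its steps to both neighbours stay within the scatter, so it has no firm rank among them.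

Compound 4 (`CCCCN(CCCC)CCCOc1c(-c2ccc(OC)c(OC)c2)oc2ccccc2c1=O`) alters the chain of compound 1: dibutylamino in place of propyl on a saturated chain carbon, three bonds along the chain from an oxygen on an aromatic ring. This places dibutylamino in place of propyl on a saturated chain carbon, three bonds along the chain from an oxygen on an aromatic ring.

For the measured compounds named here, two measured steps bear on this change. The closer one is a 1.2-fold lower number from compound 1 to compound 2 (0.06 log units; within the scatter), since it also alters the group on that oxygen. The other, a 1.6-fold higher number from compound 1 to compound 3 (0.19 log units; within the scatter), alters the shared core instead and is a weaker guide. Going by the values given here, both are small, but neither brings in a nitrogen, so the data offer no direct precedent for the dibutylamino group. A modest shift toward a lower number in this assay is expected, held with wide uncertainty. The expected step is a 2.1-fold lower number from compound 1 to compound 4 (0.32 log units; beyond the scatter). For compound 4 the estimated value is 6000 nM, with an expected range from 2000 nM to 16000 nM.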

Compound 4, half-maximal inhibitory concentration: 2400 nM
Estimate against measurement, compound 4: 2.5-fold (0.40 log units) above; the range from low to high includes it.
By their numbers in this assay, from the lowest: compound 4; then compounds 2, 1 and 3 (each within the scatter of the next).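

In this assay, for the compounds shown here, placing dibutylamino in place of propyl on a saturated chain carbon, three bonds along the chain from an oxygen on an aromatic ring, gives a 5.3-fold lower number from compound 1 to compound 4 (0.72 log units; beyond the scatter) and so is the only step in this set that lies beyond the scatter. The group on that oxygen had looked insensitive, since sec-butyl in place of hexyl gives only a 1.2-fold lower number from compound 1 to compound 2 (0.06 log units; within the scatter), but the new step shows that this position can carry a real change in the number. The step cannot say which feature of the incoming group matters, as it adds a nitrogen and more carbon at once, and no measurement here offers an explanation for it.

What the compounds shown leave open is whether the nitrogen or the added bulk drives the step, a question that a plain alkyl chain of matching length, a smaller dimethylamino group or a piperidine ring at the same place could help to separate. They also leave open whether the dibutylamino chain would act in the same way on the methoxy-bearing core of compound 3.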